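The compounds below may be only part of what the source reports. "The series", "measured", "known", "first", "only" and "open" are said of these compounds alone.

Going by the values given here, in a functional assay on the whole organism with Scenedesmus acutus as the target (on this read-out lower numbers stand for stronger inhibition and higher numbers for weaker inhibition), three compounds built on one shared core have numbers so far. Compound 1 (`O=C1C2=C(CCCC2)C(=O)N1c1ccc(Cl)cc1F`) gives 24.6 nM, compound 2 (`CCCOC(=O)c1cc(N2C(=O)C3=C(CCCC3)C2=O)c(F)cc1Cl`) gives 89.1 nM, and compound 3 (`CCCOC(=O)c1cc(N2C(=O)C3=C(CCCC3)C2=O)ccc1Cl`) gives 1860 nM. That last number is the highest of the three, and it lies beyond the scatter from both of the others.

Compound 4 (`CC(C)(C)OC(=O)c1cc(N2C(=O)C3=C(CCCC3)C2=O)ccc1Cl`) departs from compound 3 in the ester alone: tert-butyl in place of propyl on an oxygen next to a carbonyl group. In words, tert-butyl stands in place of propyl on an oxygen next to a carbonyl group, turning propoxycarbonyl into tert-butoxycarbonyl.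

Among the compounds with values here, no measured step changes this chain directly. The closest evidence is a 3.6-fold higher number from compound 1 to compound 2 (0.56 log units; beyond the scatter), a modest step that came with adding the whole propoxycarbonyl group. The other step, a 21-fold higher number from compound 2 to compound 3 (1.32 log units; beyond the scatter), is large, but it concerns hydrogen in place of fluoro, which is not altered here. It shows only that one small replacement can move the number a long way. The ester step was also measured with fluoro present, which compound 3 lacks, so the evidence is indirect.

A change within the ester is therefore expected to be small, with no shift beyond the scatter. The estimated step is a 1.2-fold higher number from compound 3 to compound 4 (0.09 log units; within the scatter). Compound 4 is expected at 2300 nM, with an estimated range of 750 nM to 7000 nM.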

Compound 4, half-maximal inhibitory concentration: 12900 nM
Beside the measured number, compound 4's estimate is 5.6-fold (0.75 log units) below it; measured number above the stated range.
By their numbers in this assay, from the lowest: compound 1; then compound 2; then compound 3; then compound 4.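

In this assay tert-butyl in place of propyl gives a 6.9-fold higher number from compound 3 to compound 4 (0.84 log units; beyond the scatter) and so shows that the number responds to the group on the oxygen next to a carbonyl group, not only to whether the whole propoxycarbonyl group is present. The earlier reading on this part of the molecule came from adding that whole group with fluoro present, whereas this change leaves everything else in compound 3 untouched and alters only the chain on that oxygen. Nothing shown here gives a measured reason for the rise in the number with this replacement.

From the compounds shown here alone, it remains open whether tert-butyl in place of propyl would bring a comparable rise with fluoro present, the setting of compound 2, where the number starts much lower. Also open, going by these compounds, is how the number would run with a methyl group or a longer straight chain on that oxygen, or with a carboxylic acid in place of the whole ester, so the two chains compared so far cannot be read as a trend.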